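The source may report more compounds than this note shows. Statements on the series, on what has been measured and on what is new or still open speak of the compounds shown alone.

Working notes on the series, read in a functional assay on B16 cells (Mus musculus) for inhibition; a higher number here means a weaker inhibitor, a lower number a stronger inhibitor. Compound 1 `CC(C)CN(NC(=O)OCc1ccccc1)C(=O)CN(Cc1ccccc1)NC(=O)CBr` gives 1400 nM. Compound 2 `CC(C)CN(NC(=O)OCc1ccccc1)C(=O)CN(Cc1ccccc1)NC(=O)Cc1cccc(Br)c1` stands at > 80000 nM, which is a limit of the assay and not a number. Compound 3 `CC(C)CN(NC(=O)OCc1ccccc1)C(=O)CN(Cc1ccccc1)/N=C/c1cccc(B(O)O)c1` gives 20400 nM, the higher of the two true numbers. Compound 4 `CC(C)CN(NC(=O)OCc1ccccc1)C(=O)CN(Cc1ccccc1)/N=C/c1ccc(B(O)O)cc1` has the same atoms as compound 3, joined differently: a group of 9 heavy atoms (6 carbon, 1 boron, 2 oxygen; one six-membered aromatic ring of carbon only) in place of a group of 9 heavy atoms (6 carbon, 1 boron, 2 oxygen; one six-membered aromatic ring of carbon only), on a carbon with a double bond to nitrogen. The nearest measured steps, a 15-fold higher number from compound 1 to compound 3 (1.16 log units; beyond the scatter) and an at least 3.9-fold lower number from compound 2 to compound 3 (0.59 log units; beyond the scatter), both lie beyond the scatter, but each exchanges a whole group on the amine nitrogen. Neither sets a direction for this change, so only a small step is expected, estimated as a 1.0-fold lower number from compound 3 to compound 4 (0.01 log units; within the scatter). Compound 4 is expected at 20000 nM, with an estimated range of 6000 nM to 65000 nM.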

Compound 4, half-maximal inhibitory concentration: 32600 nM
Beside the measured number, compound 4's estimate is 1.6-fold (0.21 log units) below it, within the range that was stated.
By their numbers in this assay, from the lowest: compound 1; then compounds 3 and 4 (each within the scatter of the next). At a limit, above all of these: compound 2.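

In this assay, joining the same atoms differently on a carbon with a double bond to nitrogen gives no change beyond the scatter: a 1.6-fold higher number from compound 3 to compound 4 (0.20 log units; within the scatter). The large gap to the bromo compound holds for this second arrangement too: a 23-fold higher number from compound 1 to compound 4 (1.37 log units; beyond the scatter). The remaining step, an at least 2.4-fold lower number from compound 2 to compound 4 (0.38 log units; beyond the scatter), rests on a limit of the assay for compound 2 and not on a number: the limit of > 80000 nM in this assay, at which 1 of the 4 values shown sits.

Open, on these data alone, is whether a carboxylic acid in place of the boron-bearing group on that carbon would give a number near that of compound 1. Also open, as far as these compounds go, is how an amine on the same ring would read.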